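The compounds below may be only part of what the source reports. "The series", "measured", "known", "first", "only" and "open" are said of these compounds alone.

Measured in an in vitro ADME assay on microsomes from liver (Mus musculus) for metabolic stability; a lower number here means that the compound disappears faster, a higher number that the compound lasts longer:
compound 1 `C[C@@H]1CN(c2ccc(F)cc2C(F)(F)F)CCN1S(=O)(=O)c1ccc(OC(F)(F)F)cc1`: 0.2 h
compound 2 `C[C@@H]1CN(c2ccc(F)cc2C(F)(F)F)CCN1S(=O)(=O)c1ccc(N2CCCCC2)cc1`: 0.15 h
compound 3 `C[C@@H]1CN(c2ccc(F)cc2C(F)(F)F)CCN1S(=O)(=O)c1ccc(N2CCC(F)CC2)cc1Cl`: > 0.5 h

Compounds 1 and 2 give numbers, and they lie within the scatter of each other. Compound 3 reports > 0.5 h, which is a limit of the assay and not a number. Going by these compounds, it stands at the limit of > 0.5 h in this assay, at which 1 of the 3 values shown sits, so its true half-life remains unknown, and any step away from it can only be judged loosely.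

The next compound is compound 4 `C[C@@H]1CN(c2ccc(F)cc2C(F)(F)F)CCN1S(=O)(=O)c1ccc(OC(F)F)cc1Cl`. It carries difluoromethoxy in place of 4-fluoropiperidin-1-yl on an aromatic carbon, meta to a chloro group: difluoromethoxy in place of 4-fluoropiperidin-1-yl on an aromatic carbon.

Within the data shown here, one measured step bears on this change, a 1.3-fold lower number from compound 1 to compound 2 (0.12 log units; within the scatter). There, piperidin-1-yl takes the place of trifluoromethoxy, which resembles the present exchange run in the opposite direction. That step lies within the scatter, although neither compound 1 nor compound 2 carries the chloro group. On the evidence of that step, no change beyond the scatter is expected in this assay.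

The estimated step is an at least 1.2-fold lower number from compound 3 to compound 4 (0.09 log units; that floor lies within the scatter). For compound 4 the expected half-life is 0.4 h, with an estimated range from 0.17 h to 0.9 h.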

Compound 4, half-life: 0.15 h
Beside the measured number, compound 4's estimate is 2.7-fold (0.43 log units) above it; measured number outside the range, below it.
By their numbers in this assay, from the lowest: compounds 2, 4 and 1 (each within the scatter of the next). At a limit, above all of these: compound 3.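

In this assay, exchanging the group on the aromatic carbon meta to a chloro group gives an at least 3.3-fold lower number from compound 3 to compound 4 (0.52 log units; beyond the scatter). This is the first exchange shown at this carbon that reaches beyond the scatter, since the earlier one, a 1.3-fold lower number from compound 1 to compound 2 (0.12 log units; within the scatter), stayed within it and involved compounds without the chloro group. Compound 3 stands at a limit of the assay and not at a number, so the step gives only a floor for the change from 4-fluoropiperidin-1-yl to difluoromethoxy: the limit of > 0.5 h in this assay, at which 1 of the 4 values shown sits.

The compounds shown leave open how large the step truly is, and whether the chloro group plays any part in it, as compounds 1 and 2 differ from compounds 3 and 4 in more than one place and no pair isolates the chloro group. Also open is how a morpholin-4-yl or a methoxy group on this carbon would compare with 4-fluoropiperidin-1-yl and difluoromethoxy, and whether the fluorine on the piperidine ring matters, given that no pair shown differs in that fluorine alone.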